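The compounds below may be only part of what the source reports. "The series", "measured", "known", "first", "only" and "open" are said of these compounds alone.

Measured in a functional assay on HCT-116 cells (Homo sapiens) for inhibition, read by MTT assay, with a stated time of 48 h (a higher number here means a weaker inhibitor, a lower number a stronger inhibitor), so far:

Compound 1 `COc1cc(-c2nnc(S)n2-c2ccc(N(C)C)cc2)cc(OC)c1OC` gives > 60000 nM (a limit)
Compound 2 `CCSc1nnc(-c2cc(OC)c(OC)c(OC)c2)n1-c1ccc(N(C)C)cc1` gives > 60000 nM (a limit)
Compound 3 `COc1cc(-c2nnc(SCc3ccccc3)n2-c2ccc(N(C)C)cc2)cc(OC)c1OC` gives 54000 nM (a number)

Going by the values given here, compound 3 holds the only number in this small set, and the other two values are limits (the limit of > 60000 nM in this assay, at which 2 of the 3 values shown sit). Compound 4 `COc1ccc(CSc2nnc(-c3cc(OC)c(OC)c(OC)c3)n2-c2ccc(N(C)C)cc2)cc1` has not yet been measured. It differs from compound 3 by methoxy in place of hydrogen on an aromatic carbon and so carries 4-methoxybenzyl in place of benzyl on the sulfur.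

Among the compounds with values here, only the steps at that sulfur bear on this change, and only indirectly. Ethyl in place of hydrogen gives a step that the two limits leave unreadable from compound 1 to compound 2 and benzyl in place of hydrogen gives an at least 1.1-fold lower number from compound 1 to compound 3 (0.04 log units; that floor lies within the scatter) on the same sulfur. Phenyl in place of methyl gives an at least 1.1-fold lower number from compound 2 to compound 3 (0.04 log units; that floor lies within the scatter) on the chain carbon bound to it. Within the data shown here, no measured pair shows methoxy in place of hydrogen on an aromatic carbon. No step beyond the scatter is therefore expected in this assay, though a small move towards a lower number is possible. The expected step is a 1.4-fold lower number from compound 3 to compound 4 (0.13 log units; within the scatter) as an estimate. For compound 4 the estimated value is 40000 nM with an expected range from 15000 nM to 60000 nM as its ends.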

Compound 4, half-maximal inhibitory concentration: 1150 nM
Compound 4: the middle estimate sits 35-fold (1.54 log units) above what was measured; measured number below the stated range.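

In this assay, going by these compounds alone, the aromatic carbon para to a large group on the benzyl turns out to be a sensitive place: methoxy in place of hydrogen there gives a 47-fold lower number from compound 3 to compound 4 (1.67 log units; beyond the scatter), the first step in this set to clear the scatter. The change to 4-methoxybenzyl also stands out against the other groups on the sulfur, with an at least 52-fold lower number from compound 2 to compound 4 (1.71 log units; beyond the scatter) and an at least 52-fold lower number from compound 1 to compound 4 (1.71 log units; beyond the scatter), whereas benzyl alone gave no step beyond the scatter. These last two steps are floors and not exact sizes, since compounds 1 and 2 are held at a limit: the limit of > 60000 nM in this assay, at which 2 of the 4 values shown sit.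

As far as these compounds go, it remains open whether this step is particular to methoxy or would also come with hydroxy, ethoxy or a chlorine atom on that carbon. From the compounds shown here alone, it is equally open whether methoxy on another carbon of that ring would give a comparable step.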